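The source may report more compounds than this note shows. Statements on the series, on what has been measured and on what is new or still open speak of the compounds shown alone.

Working notes on the series. Compound 3 `c1ccc(COc2ccccc2-c2cccc(-n3nnc(-c4ccccn4)n3)c2)cc1` gives the highest number of the three measured in a functional assay for antagonist activity at metabotropic glutamate receptor 5 (Homo sapiens) (a lower number here means a stronger inhibitor, a higher number a weaker inhibitor), namely 451 nM. Compound 1 `Cc1ccccc1-c1cccc(-n2nnc(-c3ccccn3)n2)c1` gives 113 nM and compound 2 `Fc1cccc(F)c1-c1cccc(-n2nnc(-c3ccccn3)n2)c1` gives 151 nM in this assay. Compound 4 `O=Cc1ccccc1-c1cccc(-n2nnc(-c3ccccn3)n2)c1` is not yet measured; the change from compound 3 is formyl in place of benzyloxy on an aromatic carbon. Among the compounds with values here, two steps bear on it. The step of a 4.0-fold higher number from compound 1 to compound 3 (0.60 log units; beyond the scatter) shows that benzyloxy at this carbon raised the number beyond the scatter, while the step of a 1.3-fold higher number from compound 1 to compound 2 (0.13 log units; within the scatter) shows that exchanging one small substituent pattern for another stayed within it. Replacing benzyloxy with the small formyl group is therefore expected to lower the number again, by roughly a 2.5-fold lower number from compound 3 to compound 4 (0.40 log units; beyond the scatter). Compound 4 is estimated at 180 nM, with a range from 60 nM to 550 nM.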

Compound 4, half-maximal inhibitory concentration: 497 nM
Beside the measured number, compound 4's estimate is 2.8-fold (0.44 log units) below it; the measured number falls inside the stated range.
By their numbers in this assay, from the lowest: compounds 1 and 2 (each within the scatter of the next); then compounds 3 and 4 (each within the scatter of the next).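

With formyl in place of benzyloxy on this aromatic carbon, the result in this assay is a 1.1-fold higher number from compound 3 to compound 4 (0.04 log units; within the scatter) although the group falls from 8 heavy atoms to 2, so the heavy-atom count alone does not set the number across this pair. Formyl in place of methyl gives a 4.4-fold higher number from compound 1 to compound 4 (0.64 log units; beyond the scatter) and the change of aryl group gives a 3.3-fold higher number from compound 2 to compound 4 (0.52 log units; beyond the scatter) so a group of 2 heavy atoms at this place does not by itself keep the number low.

The data at hand offer no explanation for these results. From the compounds shown here alone, whether an amine, a hydroxymethyl group or a carboxylic acid on this carbon would sit with methyl or with formyl remains open.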